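Cyclopropyl for ethyl on the quinolone nitrogen: compound 4

A few compounds are considered here, and "the series" means these few. Any claim that something is new, unique, unknown or untested is made for them only; others in the source may bear on it.

Measured so far:
- compound 1, `O=c1c(-c2nnc(COc3ccccc3)o2)cn(C2CC2)c2cc(N3CCNCC3)c(F)cc12`: 48.6 ug/mL
- compound 2, `O=c1c(-c2nnc(-c3ccccc3)o2)cn(C2CC2)c2cc(N3CCNCC3)c(F)cc12`: 46 ug/mL
- compound 3, `CCn1cc(-c2nnc(COc3cccc4ccccc34)o2)c(=O)c2cc(F)c(N3CCNCC3)cc21`: 127 ug/mL

In a functional assay on A549 cells (Homo sapiens) for cytotoxicity, read by MTT assay (on this read-out higher numbers stand for weaker inhibition and lower numbers for stronger inhibition), compound 3 gives the highest number of the three; compound 1 and compound 2 both sit beyond the scatter below it. Going by the values given here, the only single-point step measured, a 1.1-fold lower number from compound 1 to compound 2 (0.02 log units; within the scatter), lies within the scatter and concerns the oxadiazole substituent, not the group on the aromatic nitrogen.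

Compound 4, `O=c1c(-c2nnc(COc3cccc4ccccc34)o2)cn(C2CC2)c2cc(N3CCNCC3)c(F)cc12`, is reached from compound 3 by cyclopropyl in place of ethyl on an aromatic nitrogen. Among the compounds with values here, no measured pair isolates this change. Compound 1 differs from compound 3 in two places at once, the nitrogen substituent and the group on the oxadiazole, and its value stands well below that of compound 3. No measurement separates the two changes within that gap. Compound 4 carries the naphthyloxymethyl group of compound 3 together with the cyclopropyl of compound 1, so its number is expected to fall between those two, with wide uncertainty. For compound 4 the estimate is 70 ug/mL (range 35 ug/mL to 140 ug/mL), a step of a 1.8-fold lower number from compound 3 to compound 4 (0.26 log units; within the scatter), expected to be near the edge of the scatter.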

Compound 4, half-maximal inhibitory concentration: 96.2 ug/mL
Compound 4: middle estimate off by 1.4-fold (0.14 log units), on the low side; low and high end bracket the measured number.
By their numbers in this assay, from the lowest: compounds 2, 1, 4 and 3 (each within the scatter of the next, the first and the last beyond it).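

In this assay, going by these compounds alone, the step of a 1.3-fold lower number from compound 3 to compound 4 (0.12 log units; within the scatter) gives the first direct reading of the group on the aromatic nitrogen, and with the ((naphthalen-1-yl)oxy)methyl group held constant, cyclopropyl and ethyl cannot be told apart. Within the data shown here, the gap between compound 1 and compound 3 therefore does not rest on a step at this position that lies beyond the scatter, while naphthalen-1-yl for phenyl on the oxygen gives a 2.0-fold higher number from compound 1 to compound 4 (0.30 log units; within the scatter) and ((naphthalen-1-yl)oxy)methyl for phenyl on the aromatic carbon gives a 2.1-fold higher number from compound 2 to compound 4 (0.32 log units; beyond the scatter) as the only modest change. No evidence is available to account for any of these steps.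

On these data alone, whether the same nitrogen swap behaves alike with phenyl or phenoxymethyl on the aromatic carbon remains open. As far as these compounds go, the response to a longer chain such as n-butyl on the aromatic nitrogen also remains open.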